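A few compounds are considered here, and "the series" means these few. Any claim that something is new, unique, unknown or untested is made for them only; others in the source may bear on it.

Measured so far:
compound 1 `CC(C)c1ccccc1-c1nc(NCc2ccc(-c3cccnc3)cc2)c2ccccc2n1` – 180 nM in an assay on a protein complex for inhibition of ubiquitin carboxyl-terminal hydrolase 1/WD repeat-containing protein 48 (Homo sapiens), read by fluorescence; on this read-out lower numbers stand for stronger inhibition and higher numbers for weaker inhibition
compound 2 `FC(F)c1ccccc1-c1nc(NCc2ccc(-c3cccnc3)cc2)c2ccccc2n1` – 1400 nM in this assay

Compound 2 gives the highest of the two numbers; the step of a 7.8-fold higher number from compound 1 to compound 2 (0.89 log units; beyond the scatter) lies beyond the scatter. Compound 3 `Clc1ccccc1-c1nc(NCc2ccc(-c3cccnc3)cc2)c2ccccc2n1` differs from compound 2 by chloro in place of difluoromethyl on an aromatic carbon. Among the measured compounds shown here, no measured step matches this change; the only step at this position is a 7.8-fold higher number from compound 1 to compound 2 (0.89 log units; beyond the scatter), which suggests that the group on this carbon matters, but it gives no direction for chloro. A moderate improvement is therefore expected, with wide uncertainty, as a 2.3-fold lower number from compound 2 to compound 3 (0.37 log units; beyond the scatter). Compound 3 is estimated at 600 nM, likely between 150 nM and 2500 nM.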

Compound 3, half-maximal inhibitory concentration: 2100 nM
Estimate against measurement, compound 3: 3.5-fold (0.54 log units) below, within the range that was stated.
By their numbers in this assay, from the lowest: compound 1; then compounds 2 and 3 (each within the scatter of the next).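

The step of a 1.5-fold higher number from compound 2 to compound 3 (0.18 log units; within the scatter) means that chloro and difluoromethyl cannot be told apart on this carbon. The step of a 12-fold higher number from compound 1 to compound 3 (1.07 log units; beyond the scatter) shows that isopropyl now stands clear of two other groups here, not just one, so the earlier gap was not particular to difluoromethyl. No measured evidence available here explains this difference. Still open, from the compounds shown here alone, is whether a tert-butyl group, a methoxy group or an amine on this carbon would match isopropyl or give a lower number.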